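Amide aryl change: compound 2 to compound 3

The compounds below may be only part of what the source reports. "The series", "measured", "known", "first", "only" and "open" are said of these compounds alone.

Two members of the series have been run in a functional assay on KB cells (Homo sapiens) for antiproliferative activity, read by MTT assay; on this read-out lower numbers stand for stronger inhibition and higher numbers for weaker inhibition. Compound 1 `N#C/C(=C\c1cc(O)c(O)c([N+](=O)[O-])c1)C(=O)N(c1ccccc1)c1ccccc1` gives 104 ug/mL in this assay, and compound 2 `Cc1cccc(NC(=O)/C(C#N)=C/c2cc(O)c(O)c([N+](=O)[O-])c2)c1` gives 12.5 ug/mL in this assay, the lowest of the two numbers, with compound 1 sitting higher by a gap beyond the scatter. Compound 3 `COc1ccc(NC(=O)/C(C#N)=C/c2cc(O)c(O)c([N+](=O)[O-])c2)cc1` is not yet measured; it differs from compound 2 by 4-methoxyphenyl in place of 3-methylphenyl on an amide-type nitrogen. Among the compounds with values here, this change has no measured counterpart, so only a small step is expected, not beyond the scatter and in no fixed direction. The estimate implies a 1.2-fold higher number from compound 2 to compound 3 (0.08 log units; within the scatter). Compound 3 is estimated at 15 ug/mL in this assay, ranging from 5 ug/mL to 45 ug/mL.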

Compound 3, half-maximal inhibitory concentration: 29.2 ug/mL
Estimate against measurement, compound 3: 1.9-fold (0.29 log units) below; low and high end bracket the measured number.
By their numbers in this assay, from the lowest: compound 2; then compound 3; then compound 1.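

The amide aryl position is not silent in this assay: 4-methoxyphenyl in place of 3-methylphenyl on the amide-type nitrogen gives a 2.3-fold higher number from compound 2 to compound 3 (0.37 log units; beyond the scatter), a modest step in the weaker direction. The change alters both the substituent and its place on the ring, so the step cannot be assigned to either alone. Nothing available bears on the reason for this step.

As far as these compounds go, whether the step follows the methoxy group or its ring place stays open. So does the outcome with a phenyl carrying an amine or a carboxylic acid.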